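Adding a bromo group to compound 3

This account rests on a few compounds, and the source may have more. Where it says the series, first, only, none or still open, it means among the compounds named here.

In a functional assay on A549 cells (Homo sapiens) for antiproliferative activity, read by sulforhodamine B assay, with a stated time of 48 h (on this read-out higher numbers stand for weaker inhibition and lower numbers for stronger inhibition), compound 1 `COc1cc(C=C(C(=O)/C=C/c2cccc(OC)c2OC)C(=O)/C=C/c2cccc(OC)c2OC)cc(Br)c1O` gives 200 nM and compound 2 `COc1cc(C=C(C(=O)/C=C/c2cccc(OC)c2OC)C(=O)/C=C/c2cccc(OC)c2OC)cc(OC)c1O` gives 240 nM while compound 3 `COc1ccc(/C=C/C(=O)C(=Cc2ccc(O)c(OC)c2)C(=O)/C=C/c2ccc(OC)cc2OC)c(OC)c1` gives 590 nM as the highest of the three numbers, beyond the scatter from both others. Compound 4 `COc1ccc(/C=C/C(=O)C(=Cc2cc(Br)c(O)c(OC)c2)C(=O)/C=C/c2ccc(OC)cc2OC)c(OC)c1` differs from compound 3 in one place, counted by bromo in place of hydrogen on an aromatic carbon as bromo in place of hydrogen on an aromatic carbon, ortho to a hydroxy group. This turns 4-hydroxy-3-methoxyphenyl into 3-bromo-4-hydroxy-5-methoxyphenyl.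

No swap of hydrogen for bromo has been measured. Within the data shown here, the closest evidence is the swap of bromo for methoxy, which gave a 1.2-fold higher number from compound 1 to compound 2 (0.08 log units; within the scatter) and shows only that compound 1 keeps its low number while carrying a bromo group. Compound 1 and compound 2 also differ from compound 3 in their side arms, so a small move at most is expected. The estimated change is a 1.3-fold lower number from compound 3 to compound 4 (0.12 log units; within the scatter) and amounts to no clear shift. For compound 4 the expected range of 200 nM to 1000 nM surrounds an estimate of 450 nM for this measurement.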

Compound 4, half-maximal inhibitory concentration: 1090 nM
Estimate against measurement, compound 4: 2.4-fold (0.38 log units) below; measured number above the stated range.
By their numbers in this assay, from the lowest: compounds 1 and 2 (each within the scatter of the next); then compounds 3 and 4 (each within the scatter of the next).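

Among these compounds, this is the first direct reading of bromo in place of hydrogen: in this assay, placing bromo on the aromatic carbon ortho to a hydroxy group gives a 1.8-fold higher number from compound 3 to compound 4 (0.27 log units; within the scatter). The earlier pair could only compare bromo with methoxy on a different pair of side arms, whereas here the only thing that differs is the bromo itself, so the reading belongs to this position alone. With a step of this size, the two compounds cannot be ranked, and nothing available explains how this ring position relates to the read-out.

Still open, going by these compounds, is what an amine or a carboxylic acid on this same carbon would do to the number. The compounds shown also leave open whether hydrogen to bromo reads the same when the side arms are those of compound 1.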